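Swapping the aryl group: rat microsomal clearance of compound 4

The source may hold more compounds than are shown below. What is called first, only, known or untested is meant among the compounds shown, and "the series" means these compounds.

Measured compounds:
- compound 1, `Nc1ccc(S(=O)(=O)N2CCN(c3ncc(C(O)(C(F)(F)F)C(F)(F)F)cc3Br)CC2)cn1`, 32 mL.min-1.g-1
- compound 2, `Cn1cc(-c2cc(C(O)(C(F)(F)F)C(F)(F)F)cnc2N2CCN(S(=O)(=O)c3ccc(N)nc3)CC2)cn1`, 44 mL.min-1.g-1
- compound 3, `CS(=O)(=O)Nc1cccc(-c2cc(C(O)(C(F)(F)F)C(F)(F)F)cnc2N2CCN(S(=O)(=O)c3ccc(N)nc3)CC2)c1`, 81 mL.min-1.g-1

In an ADME assay (liver) for metabolic stability, with Liver microsome (Rattus norvegicus) as the target, using microsomes and NADPH, with a stated time of 30 min, tested at 1 uM (on this read-out higher numbers stand for fast clearance and lower numbers for slow clearance), compound 3 shows the highest of the three numbers. The step of a 1.8-fold higher number from compound 2 to compound 3 (0.27 log units; within the scatter) lies within the scatter, so those two cannot be told apart, while a 2.5-fold higher number from compound 1 to compound 3 (0.40 log units; beyond the scatter) is a modest step that does stand out.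

Compound 4, `Nc1ccc(S(=O)(=O)N2CCN(c3ncc(C(O)(C(F)(F)F)C(F)(F)F)cc3-c3cccc4[nH]ncc34)CC2)cn1`, is not yet measured. It differs from compound 3 in one place: 1H-indazol-4-yl in place of 3-(methanesulfonamido)phenyl on an aromatic carbon.

For the measured compounds named here, no measured step carries exactly this change. Going by the values given here, the steps that bear on it are those that alter the same position: a 1.4-fold higher number from compound 1 to compound 2 (0.14 log units; within the scatter) and a 2.5-fold higher number from compound 1 to compound 3 (0.40 log units; beyond the scatter), both in the direction of faster clearance, one within the scatter and one modestly beyond it. Compound 2, carrying a small group with two nitrogens at this position, sits closer to compound 1 than compound 3 does. The incoming group of compound 4 also brings two nitrogens, so a number between those of compound 2 and compound 3 seems most plausible.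

Compound 4 is therefore expected to give about 50 mL.min-1.g-1 in this assay, most likely between 25 mL.min-1.g-1 and 100 mL.min-1.g-1. That estimate means a step of a 1.6-fold lower number from compound 3 to compound 4 (0.21 log units; within the scatter), expected to stay within the scatter.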

Compound 4, intrinsic clearance in microsomes: 93 mL.min-1.g-1
The estimate for compound 4 lay 1.9-fold (0.27 log units) below the measured number; measured number inside the range.
By their numbers in this assay, from the lowest: compounds 1, 2, 3 and 4 (each within the scatter of the next, the first and the last beyond it).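

In this assay, two aromatic groups of different shape, 1H-indazol-4-yl and 3-(methanesulfonamido)phenyl, cannot be told apart at this carbon (a 1.1-fold higher number from compound 3 to compound 4 (0.06 log units; within the scatter)). The 1H-indazol-4-yl group does separate from the 1-methyl-1H-pyrazol-4-yl group (a 2.1-fold higher number from compound 2 to compound 4 (0.33 log units; beyond the scatter)) and from bromo (a 2.9-fold higher number from compound 1 to compound 4 (0.46 log units; beyond the scatter)), both modest steps. Among these compounds, then, a ring carrying nitrogen does not by itself keep the number close to that of compound 2, and compound 4 joins compound 3 as a second replacement for bromo with a step beyond the scatter.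

Nothing shown here explains these differences. Still open, going by these compounds, is whether a plain phenyl, or a phenyl bearing an amine or a carboxylic acid, would give a number nearer to that of compound 1 or compound 4.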